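This account rests on a few compounds, and the source may have more. Where it says the series, first, only, none or still open, it means among the compounds named here.

Measured compounds:
Compound 1, `CCN(CC)c1nc(Nc2ccc(C(=O)O)cc2)nc(OC(C(F)(F)F)C(F)(F)F)n1`: 900 nM
Compound 2, `CCN(CC)c1nc(Nc2ccc([N+](=O)[O-])cc2)nc(OC(C(F)(F)F)C(F)(F)F)n1`: 18000 nM

Both compounds were tested in an assay on cells for activation of Cystic fibrosis transmembrane conductance regulator (Homo sapiens), read by fluorescence, with stated times of 10 min and 12 s; a lower number here means that less compound is needed, a higher number that more compound is needed for the effect. Among the measured compounds shown here, compound 2 stands at the highest of the two numbers; its only neighbour is compound 1, and the step of a 20-fold higher number from compound 1 to compound 2 (1.30 log units; beyond the scatter) shows how far the two lie apart. The two compounds share one core and differ only in the group on the phenyl ring that hangs from the amine nitrogen, so this single change already moves the number a long way.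

Compound 3, `CCN(CC)c1nc(Nc2ccc3cn[nH]c3c2)nc(OC(C(F)(F)F)C(F)(F)F)n1`, differs from compound 2 by 1H-indazol-6-yl in place of 4-nitrophenyl on a nitrogen on an aromatic ring. For the measured compounds named here, only one measured step bears on this place, the step from compound 1 to compound 2, and it was large. It shows that what sits on the aromatic ring attached to that nitrogen matters, but it says nothing about exchanging the whole ring for a fused bicyclic one with a hydrogen-bond donor. Going by the values given here, since compound 2 gives the higher of the two known numbers, the expected step is a 6.0-fold lower number from compound 2 to compound 3 (0.78 log units; beyond the scatter), downward but uncertain. Compound 3 is therefore estimated at 3000 nM, in a range from 500 nM to 18000 nM.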

Compound 3, half-maximal effective concentration: 900 nM
For compound 3 the middle estimate is 3.3-fold (0.52 log units) above the measured one; the range from low to high includes it.
By their numbers in this assay, from the lowest: compounds 1 and 3 (each within the scatter of the next); then compound 2.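

In this assay, the exchange of 4-nitrophenyl for 1H-indazol-6-yl gives a 20-fold lower number from compound 2 to compound 3 (1.30 log units; beyond the scatter), so a good number at this place does not depend on keeping a single six-membered ring: a fused pair of rings serves as well. The exchange of 4-carboxyphenyl for 1H-indazol-6-yl gives no change at the digits printed from compound 1 to compound 3 (within the scatter), which means that two quite different groups on this nitrogen land at the same number, and among the three compounds only the 4-nitrophenyl group stands apart. Nothing at hand explains why these groups compare as they do, since the compounds are described only by this one read-out.

The compounds shown leave open whether other groups on the phenyl ring, such as an amine or a methoxy group, would match the carboxylic acid, and whether an indole, which has a carbon in place of one indazole nitrogen, would match the indazole. They also leave open how much the rest of the shared core contributes, for instance whether methyl or longer chains could replace the two ethyl groups on the other nitrogen.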